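The compounds below may be only part of what the source reports. "The series", "measured", "known", "first", "only" and "open" are said of these compounds alone.

Measured so far:
compound 1 `O=C(Nc1cc(Cl)ccc1O)c1noc2c1CCC2` — 373 nM
compound 2 `Cc1nc(C(=O)Nc2cccc(F)n2)c(C)n1-c1ccc(F)cc1` — 24.2 nM

Both numbers come from a functional assay on HEK293 cells for negative allosteric modulation of metabotropic glutamate receptor 5 (Homo sapiens), read by FLIPR and calcium flux; on this read-out higher numbers stand for weaker inhibition and lower numbers for stronger inhibition. Compound 2 stands at the lower of the two; its nearest neighbour is compound 1, and the gap between them is beyond the scatter. Among the compounds with values here, no pair differing in one place has been measured, so no step size is established. Compound 3 `Cc1nc(C(=O)Nc2ccnc(Cl)n2)c(C)n1-c1ccc(F)cc1` carries the change (2-chloropyrimidin-4-yl in place of 6-fluoropyridin-2-yl on an amide-type nitrogen). Without a measured step of this kind, the expectation is a modest step of about a 1.7-fold higher number from compound 2 to compound 3 (0.22 log units; within the scatter), toward a weaker reading, possibly within the scatter. Compound 3 is expected at 40 nM, with a range from 10 nM to 160 nM.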

Compound 3, half-maximal inhibitory concentration: 40.4 nM
Estimate against measurement, compound 3: 1.0-fold (0.00 log units) below; the range from low to high includes it.
By their numbers in this assay, from the lowest: compounds 2 and 3 (each within the scatter of the next); then compound 1.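

In this assay, within the data shown here, a 1.7-fold higher number from compound 2 to compound 3 (0.22 log units; within the scatter) gives the series its one measured step between compounds that differ in one place. At this amide-type nitrogen, 2-chloropyrimidin-4-yl can therefore stand in for 6-fluoropyridin-2-yl, with a second ring hetero atom and chlorine for fluorine, and the two readings cannot be told apart. Nothing available explains this result.

Among these compounds, the single step does not separate the effect of the extra ring nitrogen from that of the halogen exchange. On these data alone, whether a plain phenyl ring or a cyclohexyl group would hold the reading at this nitrogen remains open.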